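The compounds below may be only part of what the source reports. "The series", "measured", "known", "first", "only" and "open" are said of these compounds alone.

In a functional assay on DU-145 cells (Homo sapiens) for antiproliferative activity, read by propidium iodide staining, with a stated time of 96 h (a lower number here means a stronger inhibitor, a higher number a weaker inhibitor), three compounds have been measured:
- compound 1 `CC(O)(CSc1ccc(S(F)(F)(F)(F)F)cc1)C(=O)Nc1ccc(C#N)cc1C(F)(F)F` gives 17700 nM
- compound 2 `CC(O)(CSc1ccccc1OC(F)(F)F)C(=O)Nc1cccc(S(F)(F)(F)(F)F)c1` gives 17500 nM
- compound 3 `CC(O)(COc1cccc(S(F)(F)(F)(F)F)c1)C(=O)Nc1cc(C(F)(F)F)cc(C(F)(F)F)c1` gives 5700 nM

Compound 3 has the lowest number of the three, and its gap to each of the other two lies beyond the scatter of repeated measurements. Compound 1 and compound 2 lie within the scatter of each other.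

Compound 4 `CC(O)(COc1cccc(C(F)(F)C(F)(F)F)c1)C(=O)Nc1cc(C(F)(F)F)cc(C(F)(F)F)c1` has not yet been measured. It differs from compound 3 in one place: a group of 7 heavy atoms (2 carbon, 5 fluorine; no ring) in place of a group of 6 heavy atoms (5 fluorine, 1 sulfur; no ring), on an aromatic carbon on an aromatic carbon of a six-membered aromatic ring of carbon only, meta to a large group. The entering group is 1,1,2,2,2-pentafluoroethyl, and like the group it replaces it has no ring and no net charge.

For the measured compounds named here, no two measured compounds differ in only one place, so the data give no direct measure of such a change. Taking compound 3 at 5700 nM as the starting point, and given how closely the two groups match in what is counted, in this assay no change beyond the scatter is expected. The expected size is a 1.1-fold higher number from compound 3 to compound 4 (0.02 log units; within the scatter) and so stays within the scatter. For compound 4 the estimate is 6000 nM (expected range from 2500 nM to 14000 nM).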

Compound 4, half-maximal inhibitory concentration: 8500 nM
Estimate against measurement, compound 4: 1.4-fold (0.15 log units) below, and the stated range covers the measured number.
By their numbers in this assay, from the lowest: compounds 3 and 4 (each within the scatter of the next); then compounds 2 and 1 (each within the scatter of the next).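

In this assay, for the compounds shown here, the step of a 1.5-fold higher number from compound 3 to compound 4 (0.17 log units; within the scatter) is the first one-place change in this set, and it replaces the group of 6 heavy atoms (5 fluorine, 1 sulfur) with 1,1,2,2,2-pentafluoroethyl on an aromatic carbon, meta to a large group. Because the step lies within the scatter, this read-out cannot tell the two groups apart at this position on this core, a comparison the three earlier compounds could not offer, as no two of them differed in only one place. No measured information on these compounds bears on this result.

The compounds shown leave open whether a group of a different kind at this position, such as an amine, a carboxylic acid or a longer perfluoroalkyl chain, would shift the number beyond the scatter. They also leave open whether the same exchange of groups would stay within the scatter on the core of compound 1 or of compound 2, where the other parts of the molecule differ.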